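Fluoro for methyl on a bromomethyl lactone

The source may hold more compounds than are shown below. What is called first, only, known or untested is meant among the compounds shown, and "the series" means these compounds.

Measured in a functional assay on A-431 cells (Homo sapiens) for antiproliferative activity, read by sulforhodamine B assay, with a stated time of 72 h; a higher number here means a weaker inhibitor, a lower number a stronger inhibitor:
Compound 1 `C=C1CC(CBr)(c2ccc(C)cc2)OC1=O`: 2200 nM
Compound 2 `C=C1CC(CBr)(c2ccccc2OC)OC1=O`: 2400 nM

The two values lie within the scatter of each other, so compound 1 stands level with compound 2 and neither can be ranked. Compound 3 `C=C1CC(CBr)(c2ccc(F)cc2)OC1=O` has not yet been measured. It differs from compound 1 by fluoro in place of methyl on an aromatic carbon. Going by the values given here, no measured pair shows a change of this kind, so nothing beyond the scatter is expected in this assay. The expected change is a 1.1-fold higher number from compound 1 to compound 3 (0.06 log units; within the scatter). For compound 3 the estimate is 2500 nM, with an expected range from 1100 nM to 5500 nM.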

Compound 3, half-maximal inhibitory concentration: 800 nM
Beside the measured number, compound 3's estimate is 3.1-fold (0.49 log units) above it; the whole stated range lies above it.
By their numbers in this assay, from the lowest: compound 3; then compounds 1 and 2 (each within the scatter of the next).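

The aromatic carbon para to a group of 9 heavy atoms proves sensitive to what it carries: in this assay, fluoro in place of methyl gives a 2.8-fold lower number from compound 1 to compound 3 (0.44 log units; beyond the scatter), a modest step but one beyond the scatter. Before this, no step at this position could be read. No measurement at hand explains the step. Going by these compounds, whether chloro, trifluoromethyl or an amine on this carbon would move the number the same way stays open. So does whether fluoro would give a similar step on another carbon of the ring.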